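A few compounds are considered here, and "the series" means these few. Any claim that something is new, unique, unknown or untested is made for them only; others in the source may bear on it.

Measured in a functional assay on NSCLC cells (Homo sapiens) for inhibition; on this read-out lower numbers stand for stronger inhibition of growth and higher numbers for weaker inhibition of growth:
- Compound 1 `CN1C/C(=C\c2cccs2)C(O)/C(=C/c2cccs2)C1`: > 100000 nM
- Compound 2 `CN1C/C(=C\c2cccs2)C2=NN(C)C(c3cccs3)C2C1`: > 100000 nM

Both entries are limits of the assay, not numbers. Compound 2 stands at a limit, > 100000 nM. Its place therefore has no exact number, and the same holds for its neighbour: the data show (the limit of > 100000 nM in this assay, at which 2 of the 2 values shown sit).

Compound 3 `CN1C/C(=C\c2cccs2)C2=NN(c3ccccc3)C(c3cccs3)C2C1` keeps the rest of compound 2 but carries phenyl in place of methyl on an amine nitrogen in a ring.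

Among the measured compounds shown here, no measured pair shows what a change like this does in this assay, so any expectation is tentative. A modest step towards stronger inhibition of growth is expected, and the estimated step is an at least 2.0-fold lower number from compound 2 to compound 3 (0.30 log units; that floor lies within the scatter). The assay may well report only a limit again. For compound 3 the estimated value is 50000 nM, with an expected range from 15000 nM to 100000 nM.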

Compound 3, concentration for total growth inhibition: > 100000 nM
Compound 3: only a limit was reported; the forecaster's own chance of this, stated with the estimate: 55%; middle value at least 2.0-fold (0.30 log units) away from the limit.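

Compound 2 and compound 3 both give only a limit in this assay, so no step can be read for phenyl in place of methyl: the limit of > 100000 nM in this assay, at which 3 of the 3 values shown sit.

The compounds shown leave open whether this change alters inhibition of growth at all, and what change to the shared core would bring a measurable number.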